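Amino Ester Side Chains on a Shared Core

The source may hold more compounds than are shown below. What is called first, only, known or untested is meant among the compounds shown, and "the series" means these compounds.

Measured compounds in a functional assay on Bel-7402 cells (Homo sapiens) for cytotoxicity, read by MTT assay, with a stated time of 24 h; a lower number here means a stronger inhibitor, a higher number a weaker inhibitor:
compound 1, `COC(=O)[C@@H](CC(C)C)NC(=O)Cn1cc(C2=C(c3c[nH]c4ccccc34)C(=O)N(C)C2=O)c2ccccc21`, gives 42400 nM.
compound 2, `COC(=O)[C@@H](C)NC(=O)Cn1cc(C2=C(c3c[nH]c4ccccc34)C(=O)N(C)C2=O)c2ccccc21`, gives 9340 nM.
compound 3, `COC(=O)[C@H](NC(=O)Cn1cc(C2=C(c3c[nH]c4ccccc34)C(=O)N(C)C2=O)c2ccccc21)[C@@H](C)O`, is reported only as a limit, > 100000 nM.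

Compound 2 holds the lowest of the two numbers in this assay; its nearest neighbour is compound 1, with a 4.5-fold lower number from compound 1 to compound 2 (0.66 log units; beyond the scatter). Compound 3 sits at the limit (the limit of > 100000 nM in this assay, at which 1 of the 3 values shown sits), and its steps from compound 1 and compound 2 are an at least 2.3-fold higher number from compound 1 to compound 3 (0.37 log units; beyond the scatter) and an at least 10-fold higher number from compound 2 to compound 3 (1.02 log units; beyond the scatter).

Compound 4, `COC(=O)[C@H](NC(=O)Cn1cc(C2=C(c3c[nH]c4ccccc34)C(=O)N(C)C2=O)c2ccccc21)C(C)C`, differs from compound 2 by isopropyl in place of methyl on a saturated chain carbon bound to an amide-type nitrogen and a carbonyl carbon. The step that bears on this is a 4.5-fold lower number from compound 1 to compound 2 (0.66 log units; beyond the scatter), where the loss of branching on that chain carbon lowered the number; here branching is added, so a modest rise beyond the scatter is expected, giving a 2.7-fold higher number from compound 2 to compound 4 (0.43 log units; beyond the scatter). Compound 4 is therefore estimated at 25000 nM, between 9000 nM and 70000 nM.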

Compound 4, half-maximal inhibitory concentration: 4010 nM
For compound 4 the middle estimate is 6.2-fold (0.79 log units) above the measured one; the measured number lies below the stated range.
By their numbers in this assay, from the lowest: compound 4; then compound 2; then compound 1. At a limit, above all of these: compound 3.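

For the compounds shown here, with isopropyl on the saturated chain carbon bound to an amide-type nitrogen and a carbonyl carbon, compound 4 has the lowest number so far in this assay, with a 2.3-fold lower number from compound 2 to compound 4 (0.37 log units; beyond the scatter) and an 11-fold lower number from compound 1 to compound 4 (1.02 log units; beyond the scatter). The rise from methyl to isobutyl therefore does not extend to isopropyl, so the number does not follow the size of the group at this place. The 1-hydroxyethyl group stands far apart, with an at least 24-fold lower number from compound 3 to compound 4 (1.39 log units; beyond the scatter), and the value of compound 3 is a limit: the limit of > 100000 nM in this assay, at which 1 of the 4 values shown sits.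

The compounds shown leave open how a longer unbranched chain or an amine on this carbon would read, and whether a carboxylic acid in place of the methyl ester would keep the number this low.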